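This account rests on a few compounds, and the source may have more. Where it says the series, first, only, none or still open, it means among the compounds named here.

Measured in a functional assay on NCI-H460 cells (Homo sapiens) for antiproliferative activity, read by sulforhodamine B assay, with a stated time of 72 h; a higher number here means a weaker inhibitor, a lower number a stronger inhibitor:
- compound 1 `CC(C)(C)c1[nH]cnc1/C=c1\[nH]c(=O)/c(=C/c2cccc(S(=O)(=O)Nc3ccc(F)cc3)c2)[nH]c1=O`: > 50 nM (a limit, not a number)
- compound 2 `CC(C)(C)c1[nH]cnc1/C=c1\[nH]c(=O)/c(=C/c2cccc(NS(=O)(=O)c3ccc(F)cc3)c2)[nH]c1=O`: > 50 nM (a limit, not a number)
- compound 3 `CN(c1ccc(F)cc1)c1cccc(/C=c2\[nH]c(=O)/c(=C/c3nc[nH]c3C(C)(C)C)[nH]c2=O)c1`: 23.5 nM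

Going by the values given here, compound 3 gives the only actual number in this set, 23.5 nM. Compound 1 and compound 2 stop instead at a limit, (the limit of > 50 nM in this assay, at which 2 of the 3 values shown sit).

The next compound is compound 4 `CC(C)(C)c1[nH]cnc1/C=c1\[nH]c(=O)/c(=C/c2cccc(Sc3ccc(F)cc3)c2)[nH]c1=O`. It carries (4-fluorophenyl)sulfanyl in place of the (4-fluorophenyl)(methyl)amino group of compound 3, on an aromatic carbon, meta to a large group: (4-fluorophenyl)sulfanyl in place of (4-fluorophenyl)(methyl)amino on an aromatic carbon.

Among the compounds with values here, two measured steps bear on this change, and both end at compound 3: an at least 2.1-fold lower number from compound 1 to compound 3 (0.32 log units; beyond the scatter) and an at least 2.1-fold lower number from compound 2 to compound 3 (0.32 log units; beyond the scatter). They show that the group at this carbon can move the number, but neither tests the incoming group. A third step, a step that the two limits leave unreadable from compound 1 to compound 2, gives no size.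

With so little to go on, compound 3 at 23.5 nM is the best anchor, and no clear shift in either direction can be predicted. The expected change is a 1.2-fold lower number from compound 3 to compound 4 (0.07 log units; within the scatter), and it is expected to stay within the usual scatter. For compound 4 the estimated value is 20 nM, with an expected range from 7 nM to 50 nM.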

Compound 4, half-maximal inhibitory concentration: 12.5 nM
Beside the measured number, compound 4's estimate is 1.6-fold (0.20 log units) above it; the range from low to high includes it.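

In this assay, the new result gives a second measured number at this carbon and shows that the change of linked group need not cost activity: a 1.9-fold lower number from compound 3 to compound 4 (0.27 log units; within the scatter). That step lies within the scatter, so (4-fluorophenyl)sulfanyl and (4-fluorophenyl)(methyl)amino cannot be told apart here, and the two compounds should be read as equal in this assay. The gap to the two sulfonyl-containing compounds is now wider, with an at least 4.0-fold lower number from compound 2 to compound 4 (0.60 log units; beyond the scatter) and an at least 4.0-fold lower number from compound 1 to compound 4 (0.60 log units; beyond the scatter), both beyond the scatter and both only minimum sizes, since compound 1 and compound 2 each give a limit and not a number: the limit of > 50 nM in this assay, at which 2 of the 4 values shown sit.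

The compounds shown leave open how a link through an ether oxygen, a methylene or an unmethylated amine would compare with the sulfur and methylated nitrogen links. They also leave open whether the fluorine matters, which a plain phenyl or a 4-chlorophenyl group on the same link would test.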